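A few compounds are considered here, and "the series" means these few. Any claim that something is new, unique, unknown or untested is made for them only; others in the source may bear on it.

Three compounds with a shared core were tested in a functional assay on MGC-803 cells (Homo sapiens) for inhibition, read by MTT assay, with a stated time of 72 h; a lower number here means a stronger inhibitor, a higher number a weaker inhibitor. Compound 1 `Cc1cc(Nc2cc(-c3ccccc3)[nH]n2)n2nc(SCc3ccc([N+](=O)[O-])cc3)nc2n1` gives 4250 nM in this assay. Compound 2 `Cc1cc(Nc2cc(-c3ccccc3)[nH]n2)n2ncnc2n1` carries a hydrogen where compound 1 carries the (4-nitrobenzyl)sulfanyl group, and compound 2 gives 21700 nM, the highest number of the three. The step of a 5.1-fold higher number from compound 1 to compound 2 (0.71 log units; beyond the scatter) shows this plainly. Compound 3 `Cc1cc(Nc2cc(-c3ccccc3)[nH]n2)n2nc(SCc3ccc(F)cc3)nc2n1` gives 3270 nM in this assay. Against compound 1 the step is a 1.3-fold lower number from compound 1 to compound 3 (0.11 log units; within the scatter), so those two numbers lie close together, while the step of a 6.6-fold lower number from compound 2 to compound 3 (0.82 log units; beyond the scatter) is again clear.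

Compound 4 `Cc1cc(Nc2cc(-c3ccccc3)[nH]n2)n2nc(SCc3ccccc3Br)nc2n1` has not been measured. It differs from compound 2 in one place: (2-bromobenzyl)sulfanyl in place of hydrogen on an aromatic carbon. The two steps that bear on this change are a 5.1-fold higher number from compound 1 to compound 2 (0.71 log units; beyond the scatter) and a 6.6-fold lower number from compound 2 to compound 3 (0.82 log units; beyond the scatter). Both times such a group in place of hydrogen on that carbon went with a clearly lower number, and the two groups gave numbers close to each other. Within the data shown here, the group entering here carries bromine rather than nitro or fluoro, a variation no measured compound tests directly, so the expectation rests on those two steps alone. The expected step is therefore a 5.4-fold lower number from compound 2 to compound 4 (0.73 log units; beyond the scatter), toward a lower number. Compound 4 is estimated to give 4000 nM, with a range from 1500 nM to 11000 nM.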

Compound 4, half-maximal inhibitory concentration: 3650 nM
Compound 4: the middle estimate sits 1.1-fold (0.04 log units) above what was measured; low and high end bracket the measured number.
By their numbers in this assay, from the lowest: compounds 3, 4 and 1 (each within the scatter of the next); then compound 2.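

The drop on adding a group to this carbon between two ring nitrogen atoms now holds for a third group: in this assay, (2-bromobenzyl)sulfanyl in place of hydrogen gives a 5.9-fold lower number from compound 2 to compound 4 (0.77 log units; beyond the scatter). The identity and place of the substituent on the benzyl ring made no difference that can be read, since bromine at the 2 position gives a 1.1-fold higher number from compound 3 to compound 4 (0.05 log units; within the scatter) against 4-fluoro and a 1.2-fold lower number from compound 1 to compound 4 (0.07 log units; within the scatter) against 4-nitro, and both steps lie within the scatter. Across these three compounds, then, the step from hydrogen to a substituted benzylsulfanyl group stands out, while the choice among these three substituents does not separate them, and nothing available here explains either observation.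

All three active groups share the sulfur link and the benzyl ring, so the compounds shown leave open which of these parts goes with the lower numbers. A plain methylsulfanyl group, an unsubstituted benzylsulfanyl group, or an amine on the same carbon would help separate the contribution of the sulfur from that of the ring.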